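Taking the chloro group off compound 3

This account rests on a few compounds, and the source may have more. Where it says the series, first, only, none or still open, it means among the compounds named here.

In a functional assay on HL-60 cells (Homo sapiens) for cytotoxicity, read by CCK-8 assay, with a stated time of 24 h (on this read-out lower numbers stand for stronger inhibition and higher numbers for weaker inhibition), compound 1 `C=CC(=O)N1C(=O)CC(C)Sc2ccccc21` reads 199000 nM and compound 2 `C=CC(=O)N1C(=O)CC(c2ccccc2Cl)Sc2ccccc21` reads 91400 nM, while compound 3 `C=CC(=O)N1C(=O)CC(c2cccc(Cl)c2)Sc2ccccc21` reads 93100 nM in the same test. Compound 3 therefore lies within the scatter of compound 2 and holds a lower number than compound 1. Going by the values given here, compound 4 `C=CC(=O)N1C(=O)CC(c2ccccc2)Sc2ccccc21` departs from compound 3 through hydrogen in place of chloro on an aromatic carbon as its only change: hydrogen in place of chloro on an aromatic carbon, so that 3-chlorophenyl becomes phenyl.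

Among the compounds with values here, no measured step removes a chloro group alone. The nearest evidence is a 2.1-fold lower number from compound 1 to compound 3 (0.33 log units; beyond the scatter) and a 2.2-fold lower number from compound 1 to compound 2 (0.34 log units; beyond the scatter), both modest and both replacing methyl with a chlorinated aryl group, along with a 1.0-fold higher number from compound 2 to compound 3 (0.01 log units; within the scatter), which stays within the scatter. Since those steps are so small, only a slight move towards a higher number is expected, possibly none beyond the scatter. The expected change is a 1.2-fold higher number from compound 3 to compound 4 (0.07 log units; within the scatter) in this estimate. Compound 4 is estimated at 110000 nM in this assay, with an expected range from 65000 nM to 185000 nM overall.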

Compound 4, half-maximal inhibitory concentration: 97400 nM
Beside the measured number, compound 4's estimate is 1.1-fold (0.05 log units) above it; measured number inside the range.
By their numbers in this assay, from the lowest: compounds 2, 3 and 4 (each within the scatter of the next); then compound 1.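

With the chloro group gone altogether, the aryl position in this assay shows no dependence on that atom: the bare phenyl gives a 1.0-fold higher number from compound 3 to compound 4 (0.02 log units; within the scatter) and, against the other chlorinated compound, a 1.1-fold higher number from compound 2 to compound 4 (0.03 log units; within the scatter). The drop in number seen earlier on leaving methyl therefore does not need chlorine, since phenyl alone gives a 2.0-fold lower number from compound 1 to compound 4 (0.31 log units; beyond the scatter), so among these compounds the step from methyl to an aryl group accounts for the whole difference. Nothing measured on these compounds explains why the chloro group counts for so little here.

As far as these compounds go, whether a substituent other than chloro on this phenyl, such as a methoxy group, an amine or a carboxylic acid, would move the number beyond the scatter stays open. So does the outcome of a longer alkyl chain or a saturated ring in place of phenyl on the same carbon.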